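This account rests on a few compounds, and the source may have more. Where it says the series, first, only, none or still open, it means among the compounds named here.

In a functional assay on DU-145 cells (Homo sapiens) for antiproliferative activity, read by sulforhodamine B assay, with a stated time of 3 days (on this read-out lower numbers stand for stronger inhibition of growth and higher numbers for weaker inhibition of growth), compound 1 `CN1CCC(C(=O)Nc2cccc(Nc3ncc(F)c(Nc4ccc(F)cc4)n3)c2)CC1` gives 1150 nM, compound 2 `O=C(Nc1cccc(Nc2ncc(F)c(Nc3ccc(F)cc3)n2)c1)c1ccncc1` gives 4330 nM and compound 3 `O=C(Nc1cc(Cl)cc(Cl)c1)c1cccc(Nc2ncc(F)c(Nc3ccc(F)cc3)n2)c1` gives 17500 nM, the highest number of the three. Compound 4 `Cn1ccnc1NC(=O)c1cccc(Nc2ncc(F)c(Nc3ccc(F)cc3)n2)c1` keeps the shared core and the carbamoyl link of compound 3 and alters only the group on the amide-type nitrogen: 1-methyl-1H-imidazol-2-yl in place of 3,5-dichlorophenyl on an amide-type nitrogen. Among the compounds with values here, no measured step makes this exact exchange, so the evidence is indirect. The closest guides are a 4.0-fold higher number from compound 2 to compound 3 (0.61 log units; beyond the scatter) and a 15-fold higher number from compound 1 to compound 3 (1.18 log units; beyond the scatter), each of which brings in the (3,5-dichlorophenyl)carbamoyl group and ends at a higher number. Both steps also replace the whole amide-bearing group, so they bear on the change only loosely. The step of a 3.8-fold higher number from compound 1 to compound 2 (0.58 log units; beyond the scatter) shows that exchanging one ring on a carbonyl carbon for another can also move the number beyond the scatter. A modest move to a lower number is therefore expected, with the estimated step being a 3.5-fold lower number from compound 3 to compound 4 (0.54 log units; beyond the scatter). Compound 4 is estimated at 5000 nM, with an expected range from 1800 nM to 16000 nM.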

Compound 4, concentration for 50% growth inhibition: 15100 nM
Compound 4: middle estimate off by 3.0-fold (0.48 log units), on the low side, within the range that was stated.
By their numbers in this assay, from the lowest: compound 1; then compound 2; then compounds 4 and 3 (each within the scatter of the next).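

The exchange on the amide-type nitrogen, from 3,5-dichlorophenyl to 1-methyl-1H-imidazol-2-yl, leaves the number in this assay essentially unchanged, with a 1.2-fold lower number from compound 3 to compound 4 (0.06 log units; within the scatter), even though the entering ring brings 2 hydrogen-bond acceptors and the leaving ring none. The higher numbers of the carbamoyl compounds therefore do not depend on the dichlorophenyl ring alone, as a 3.5-fold higher number from compound 2 to compound 4 (0.54 log units; beyond the scatter) and a 13-fold higher number from compound 1 to compound 4 (1.12 log units; beyond the scatter) also show with the imidazole ring in place. The data offer no measured basis for explaining this lack of change.

From the compounds shown here alone, it remains open whether a 2-(dimethylamino)ethyl chain or a carboxylic acid on the amide-type nitrogen would give a lower number. Nor can the effect of the carbamoyl link be separated from that of its substituent, since every step to it also replaces the ring.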